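The compounds below may be only part of what the source reports. "The series", "measured", "known", "first", "only" and "open" are said of these compounds alone.

Of the compounds shown here, three have so far been measured in an assay for inhibition of 17-beta-hydroxysteroid dehydrogenase type 1 (Homo sapiens), read by HPLC, with a stated time of 10 min, tested at 1 uM; on this read-out higher numbers stand for more inhibition at the one concentration tested (going by the name of the read-out) and lower numbers for less inhibition. Compound 1 `Oc1cc(Oc2cccc(-c3cccc(O)c3F)n2)ccc1F` gives 69%. Compound 2 `O=C(c1ccc(F)c(O)c1)c1ccc2cc(O)ccc2n1` gives 20%. Compound 3 `Nc1ccc2ccc(C(=O)c3ccc(F)c(O)c3)nc2c1` gives 21%, the second highest of the three numbers: its value and that of compound 2 lie within the scatter of each other, while the value of compound 1 stands beyond the scatter above it.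

Compound 4 `O=C(O)CNc1ccc2ccc(C(=O)c3ccc(F)c(O)c3)nc2c1` awaits measurement. It differs from compound 3 in one place: carboxymethyl in place of hydrogen on a nitrogen on an aromatic ring. Going by the values given here, no step between measured compounds matches this change, so the expectation rests on compound 3 alone. The step of a number 3 percentage points lower from compound 3 to compound 4 (within the scatter) is expected to be small, with no direction beyond the scatter. Compound 4 is therefore estimated at 18%, within 5% to 35%.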

Compound 4, a percentage reported as inhibition, at one concentration (the size of the read-out at that concentration, not a potency): 3%
Beside the measured number, compound 4's estimate is 15 percentage points above it; the measured number lies below the stated range.
By their numbers in this assay, from the lowest: compound 4; then compounds 2 and 3 (each within the scatter of the next); then compound 1.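

Substitution on this nitrogen is not neutral in this assay: carboxymethyl in place of hydrogen gives a number 18 percentage points lower from compound 3 to compound 4 (beyond the scatter) and is the only step read at this position. The amino group of compound 3 therefore does not accept this substituent without a loss of inhibition at the one concentration tested. Nothing available bears on the cause of this loss.

On these data alone, whether the loss follows the carboxylic acid or the chain itself stays open. A methyl group, an ethyl ester or a primary amide on the same nitrogen would separate the two.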